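A few compounds are considered here, and "the series" means these few. Any claim that something is new, unique, unknown or untested is made for them only; others in the source may bear on it.

Compound 1 `COc1ccc(C2=C(c3cc(OC)c(OC)c(OC)c3)C(=O)C(O)C2)cc1NC(=O)c1ccccc1` is the starting point here. In an ADME assay on PA-1 cells (Homo sapiens) for cytotoxicity, read by MTT assay, with a stated time of 72 h (on this read-out lower numbers stand for stronger inhibition and higher numbers for weaker inhibition), compound 1 gives > 100 ug/mL, which is a limit of the assay and not a number. It therefore stands at the limit of > 100 ug/mL in this assay, at which 1 of the 2 values shown sits. The other measured compound, compound 2 `COc1ccc(C2=C(c3cc(OC)c(OC)c(OC)c3)C(=O)CC2OC(C)=O)cc1NC=O`, gives a real number of 5 ug/mL, but it differs from compound 1 in more than one place, so the two values cannot be tied to any single change.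

Compound 3 `COc1ccc(C2=C(c3cc(OC)c(OC)c(OC)c3)C(=O)C(O)C2)cc1OC(C)C`, not yet measured, keeps the shared core of compound 1 and makes one change: isopropoxy in place of benzamido on an aromatic carbon, ortho to a methoxy group (isopropoxy in place of benzamido on an aromatic carbon). Among the compounds with values here, the only guide is that compound 2, at 5 ug/mL, also lacks the benzamido group, so a large step towards stronger inhibition in this assay, beyond the usual scatter, is expected. This is a cautious expectation, and compound 3 could still stay at the limit. The expected change is an at least 8.3-fold lower number from compound 1 to compound 3 (0.92 log units; beyond the scatter). For compound 3 the estimate is 12 ug/mL, with an expected range from 2 ug/mL to 80 ug/mL.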

Compound 3, half-maximal inhibitory concentration: > 100 ug/mL
Compound 3: only a limit was reported; the forecaster's own chance of this, stated with the estimate: 20%; middle value at least 8.3-fold (0.92 log units) from the limit.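

Within the data shown here, compound 3, like compound 1, ends at a limit of the assay and not at a number, so no step between these two compounds can be read in this assay: the limit of > 100 ug/mL in this assay, at which 2 of the 3 values shown sit. Still open, as far as these compounds go, is whether isopropoxy in place of benzamido on an aromatic carbon changes inhibition at all, and by how much.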